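The source may report more compounds than this note shows. Statements on the series, on what has been measured and on what is new or still open speak of the compounds shown alone.

Compound 3 `CCOC(=O)C1=Cc2ccccc2OC1(OCc1cn(-c2ccc(F)c([N+](=O)[O-])c2)nn1)C(F)(F)F` gives the only number shown in a functional assay on DU-145 cells (Homo sapiens) for inhibition, read by MTT assay, with a stated time of 24 h (on this read-out higher numbers stand for weaker inhibition and lower numbers for stronger inhibition), namely 13200 nM. Compound 1 `CCOC(=O)C1=Cc2ccccc2OC1(OCc1cn(CC(=O)Nc2cccc(F)c2)nn1)C(F)(F)F` returns only a limit of the assay, > 150000 nM. Compound 2 `CCOC(=O)C1=Cc2ccccc2OC1(OCc1cn(CC(=O)Nc2ccc(C)cc2)nn1)C(F)(F)F` likewise returns only a limit, > 150000 nM. Compound 4 `CCOC(=O)C1=Cc2ccccc2OC1(OCc1cn(CC(=O)NC2CCCCC2)nn1)C(F)(F)F` is not yet measured; it differs from compound 3 in one place: (cyclohexylcarbamoyl)methyl in place of 4-fluoro-3-nitrophenyl on an aromatic nitrogen. Within the data shown here, the steps that bear on this run the other way, 4-fluoro-3-nitrophenyl entering for a carbamoylmethyl group: an at least 11-fold lower number from compound 1 to compound 3 (1.05 log units; beyond the scatter) and an at least 11-fold lower number from compound 2 to compound 3 (1.05 log units; beyond the scatter), each a large fall set against the limit (the limit of > 150000 nM in this assay, at which 2 of the 3 values shown sit). Reversing that change, compound 4 is expected to give a higher number, a step of an 11-fold higher number from compound 3 to compound 4 (1.06 log units; beyond the scatter). Compound 4 is therefore estimated at 150000 nM, within 40000 nM to 600000 nM.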

Compound 4, half-maximal inhibitory concentration: 10200 nM
Compound 4: middle estimate off by 15-fold (1.17 log units), on the high side, outside the stated range (below it).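

On the aromatic nitrogen, a carbamoylmethyl group does not by itself bring the read-out to the limit in this assay: (cyclohexylcarbamoyl)methyl in place of 4-fluoro-3-nitrophenyl gives a 1.3-fold lower number from compound 3 to compound 4 (0.11 log units; within the scatter). The group on the amide-type nitrogen makes the difference, with cyclohexyl in place of 4-methylphenyl giving an at least 14-fold lower number from compound 2 to compound 4 (1.16 log units; beyond the scatter) and cyclohexyl in place of 3-fluorophenyl giving an at least 14-fold lower number from compound 1 to compound 4 (1.16 log units; beyond the scatter). Both of these steps are set against a limit of the assay: the limit of > 150000 nM in this assay, at which 2 of the 4 values shown sit.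

As far as these compounds go, what a cyclopentyl group or an open-chain hexyl group would give on the amide-type nitrogen stays open. So does whether a non-aromatic ring is needed there at all.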